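The compounds below may be only part of what the source reports. "The series", "measured", "known", "first", "only" and "open" are said of these compounds alone.

Measured compounds:
compound 1 `Clc1ccc(N2N=NCC2c2ccncc2)cc1` — 257 mg/kg
compound 2 `c1ccc(N2N=NCC2c2ccncc2)cc1` — 165 mg/kg
compound 3 `Fc1ccc(N2N=NCC2c2ccncc2)cc1` — 239 mg/kg

In a functional assay on the whole organism with Mus musculus as the target, in the maximal electroshock model (on this read-out higher numbers stand for an effect only at larger amounts of compound and lower numbers for an effect already at smaller amounts), compound 3 gives 239 mg/kg, the second highest of the three numbers; its nearest neighbour is compound 1 at 257 mg/kg, its furthest compound 2 at 165 mg/kg, and both of those gaps sit within the scatter, so the three compounds cannot be told apart on this read-out.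

Compound 4 `FC(F)(F)c1ccc(N2N=NCC2c2ccncc2)cc1` differs from compound 3 by one change: trifluoromethyl in place of fluoro on an aromatic carbon. Among the measured compounds shown here, the steps that bear on it are the earlier changes at the same aromatic carbon. The step of a 1.1-fold lower number from compound 1 to compound 3 (0.03 log units; within the scatter) and the step of a 1.4-fold higher number from compound 2 to compound 3 (0.16 log units; within the scatter) both stayed within the scatter, as did a 1.6-fold lower number from compound 1 to compound 2 (0.19 log units; within the scatter). For the measured compounds named here, nothing among the measured compounds suggests that the halogen-type substituent at this place moves the number beyond the scatter, so for compound 4 no step beyond the scatter is expected in this assay; the expected step is a 1.0-fold higher number from compound 3 to compound 4 (0.00 log units; within the scatter).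

Compound 4 is therefore estimated at 240 mg/kg, with a range from 120 mg/kg to 480 mg/kg.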

Compound 4, dose for half-maximal effect: 689 mg/kg
Compound 4: middle estimate off by 2.9-fold (0.46 log units), on the low side, outside the stated range (above it).
By their numbers in this assay, from the lowest: compounds 2, 3 and 1 (each within the scatter of the next); then compound 4.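

In this assay, the aromatic carbon where hydrogen, fluoro and chloro could not be told apart proves able to move the number: trifluoromethyl in place of fluoro gives a clear step (a 2.9-fold higher number from compound 3 to compound 4 (0.46 log units; beyond the scatter)), and the same holds against hydrogen (a 4.2-fold higher number from compound 2 to compound 4 (0.62 log units; beyond the scatter)) and chloro (a 2.7-fold higher number from compound 1 to compound 4 (0.43 log units; beyond the scatter)). Trifluoromethyl, with four heavy atoms where fluoro has one, is thus the first substituent here to pass beyond the scatter, and it does so towards an effect only at larger amounts of compound. Nothing in the data explains this shift.

Going by these compounds, whether other groups at this place, such as a methoxy, a nitrile, an amine or a carboxylic acid, would also shift the number stays open. Also open, on these data alone, is whether any change elsewhere on the shared core could bring the number down beyond the scatter.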